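From cyclopentyl to 2-methoxyphenyl on an amine nitrogen

The compounds below may be only part of what the source reports. "The series", "measured", "known", "first", "only" and "open" are said of these compounds alone.

Compound 1 `O=C1C=C(NCc2ccccc2)C(=O)c2c1nc1n2[C@H]2OC[C@@H](O)[C@H]2OC1`: 2670 nM
Compound 2 `O=C1C(NC2CCCC2)=CC(=O)c2c1nc1n2[C@H]2OC[C@@H](O)[C@H]2OC1`: > 16000 nM (a limit)
Compound 3 `O=C1C=C(Nc2ccccc2F)C(=O)c2c1nc1n2[C@H]2OC[C@@H](O)[C@H]2OC1`: 2080 nM

In a functional assay on MGC-803 cells (Homo sapiens) for inhibition, read by sulforhodamine B assay (on this read-out lower numbers stand for stronger inhibition and higher numbers for weaker inhibition), compound 2 gives > 16000 nM, which is a limit and not a number. Compound 4 `COc1ccccc1NC1=CC(=O)c2c(nc3n2[C@H]2OC[C@@H](O)[C@H]2OC3)C1=O` has not yet been measured; it carries 2-methoxyphenyl in place of cyclopentyl on an amine nitrogen. Among the measured compounds shown here, the only measured step is a 1.3-fold lower number from compound 1 to compound 3 (0.11 log units; within the scatter), which is within the scatter and does not start from compound 2. Compound 1 and compound 3 both gave numbers below that limit. Compound 3, at 2080 nM, also has a six-membered aromatic ring on the amine nitrogen. A step to a lower number in this assay is therefore expected, of uncertain size: an at least 2.6-fold lower number from compound 2 to compound 4 (0.42 log units; beyond the scatter). Compound 4 is expected at about 6000 nM, with an estimated range of 2000 nM to 16000 nM.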

Compound 4, half-maximal inhibitory concentration: 1670 nM
For compound 4 the middle estimate is 3.6-fold (0.56 log units) above the measured one, outside the stated range (below it).
By their numbers in this assay, from the lowest: compounds 4, 3 and 1 (each within the scatter of the next). At a limit, above all of these: compound 2.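

Among the compounds shown here, on the core of compound 2, the change from cyclopentylamino to (2-methoxyphenyl)amino gives the first step at this amine nitrogen that lies beyond the scatter in this assay: an at least 9.5-fold lower number from compound 2 to compound 4 (0.98 log units; beyond the scatter). The earlier compounds shown here showed only a step within the scatter, and it did not start from compound 2. Compound 2 stands at a limit, so the step is a bound and its full size stays unknown: the limit of > 16000 nM in this assay, at which 1 of the 4 values shown sits.

The compounds shown leave open whether the aromatic ring or the methoxy group carries this step. A plain phenyl on the same amine nitrogen would separate the two.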